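The source may hold more compounds than are shown below. What is called first, only, known or untested is meant among the compounds shown, and "the series" means these compounds.

Measured in a functional assay on MCF7 cells (Homo sapiens) for antiproliferative activity, read by MTT assay, with a stated time of 24 h; a higher number here means a weaker inhibitor, a lower number a stronger inhibitor:
- compound 1 `CCN(CC)CCNC(=O)C1CC(C(CC)(CC)c2ccc(C#CC(C)(C)O)c(C)c2)=CN1CC`: 3170 nM
- compound 2 `CCN(CC)CCNC(=O)C1CC(C(CC)(CC)c2ccc(C#CC(C)(O)CC)c(C)c2)=CN1CC`: 2780 nM

Not yet measured: compound 3 `CCCC(O)(C#Cc1ccc(C(CC)(CC)C2=CN(CC)C(C(=O)NCCN(CC)CC)C2)cc1C)CCC`.

Going by the values given here, compound 2 cannot be separated from compound 1, the only other measured compound. Compound 3 changes the 1-hydroxy-1-methylpropyl group on a triple-bonded carbon: a group of 8 heavy atoms (7 carbon, 1 oxygen; no ring) in place of a group of 5 heavy atoms (4 carbon, 1 oxygen; no ring), on a triple-bonded carbon. Among the compounds with values here, the only measured step bearing on this, a 1.1-fold lower number from compound 1 to compound 2 (0.06 log units; within the scatter), alters the same group. With that single step as the guide, no step beyond the scatter is expected in this assay. The estimated step is a 1.1-fold lower number from compound 2 to compound 3 (0.05 log units; within the scatter). For compound 3 the expected value is 2500 nM, with an estimated range of 1000 nM to 6000 nM.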

Compound 3, half-maximal inhibitory concentration: 1290 nM
The estimate for compound 3 lay 1.9-fold (0.29 log units) above the measured number; low and high end bracket the measured number.
By their numbers in this assay, from the lowest: compound 3; then compounds 2 and 1 (each within the scatter of the next).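

On the triple-bonded carbon, the group of 8 heavy atoms separates from the smaller groups in this assay, with a 2.2-fold lower number from compound 2 to compound 3 (0.33 log units; beyond the scatter) and a 2.5-fold lower number from compound 1 to compound 3 (0.39 log units; beyond the scatter), both modest, while the change between the two smaller groups stayed within the scatter. This position therefore accepts the larger group with no loss in this assay. No measurement available here accounts for these steps.

On these data alone, it remains open whether a longer chain on the same carbon lowers the number further, and whether an amine in place of the hydroxy group keeps it.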